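The compounds below may be only part of what the source reports. "The series", "measured", "known", "first", "only" and "open" are said of these compounds alone.

The series shares one core, carried in compound 1 `COc1cc(C)cc(-c2c(-c3ccnc(-c4ccc(C(C)=O)cc4)c3)cnn2CC#N)c1` and compound 2 `Cc1cc(O)cc(-c2nn(CC#N)cc2-c2ccnc(-c3ccc(N(C)C)cc3)c2)c1`. In a functional assay on MDA-MB-468 cells (Homo sapiens) for inhibition, read by sulforhodamine B assay, with a stated time of 48 h (a lower number here means a stronger inhibitor of growth, a higher number a weaker inhibitor of growth), compound 1 gives 1430 nM. In this assay compound 2 gives 1630 nM; the two numbers sit within the scatter of each other, so neither can be placed ahead of the other, and compound 1 merely holds the lower of the two numbers shown. Compound 3 `COc1cc(C)cc(-c2c(-c3ccnc(-c4ccc(N(C)C)cc4)c3)cnn2CC#N)c1` is not yet measured. It differs from compound 1 in one place: dimethylamino in place of acetyl on an aromatic carbon. For the measured compounds named here, no pair of measured compounds shows the size of this step on its own, so there is no direct precedent. Compound 2 carries the same dimethylamino group on the same aromatic carbon and differs from compound 1 elsewhere, and its number stays within the scatter of compound 1; this is the only indirect hint, and it points to no movement beyond the scatter. For compound 3 the expected step of a 1.0-fold higher number from compound 1 to compound 3 (0.02 log units; within the scatter) is therefore small in either direction. The estimate for compound 3 is 1500 nM, expected to lie between 700 nM and 3200 nM.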

Compound 3, concentration for 50% growth inhibition: 26.1 nM
For compound 3 the middle estimate is 57-fold (1.76 log units) above the measured one; the whole stated range lies above it.
By their numbers in this assay, from the lowest: compound 3; then compounds 1 and 2 (each within the scatter of the next).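

In this assay, exchanging 4-acetylphenyl for 4-(dimethylamino)phenyl gives a 55-fold lower number from compound 1 to compound 3 (1.74 log units; beyond the scatter), so a single change on this aromatic carbon, para to a large group, can move the number far beyond the scatter on the core of compound 1. Acetyl and dimethylamino have the same count of heavy atoms, the same counts of hydrogen-bond donors and acceptors and no net charge, so those counts do not separate the two groups, even though the step is large. Nothing measured here accounts for the step.

On these data alone, this is one exchange at one position, so it remains open whether a different nitrogen group on the same carbon, such as methylamino, a primary amine or morpholine, would keep the lower number, or whether a carboxylic acid there would give a number closer to that of compound 1. Compound 2 differs from compound 3 in more than one place, so the contribution of the rest of the core alongside dimethylamino cannot be read.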